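A few compounds are considered here, and "the series" means these few. Any claim that something is new, unique, unknown or untested is made for them only; others in the source may bear on it.

Compound 1, `CC[C@@H](c1nc2ccc(C(=O)O)cc2n1C)N1C(=O)CN(c2ccc(Oc3ccccc3)cc2)C1=O`, is the starting point of this account. Among the compounds with values here, in an assay on isolated protein for inhibition of Bile acid receptor (Homo sapiens), read by TR-FRET and LanthaScreen (a lower number here means a stronger inhibitor, a higher number a weaker inhibitor), compound 1 gives 210000 nM, the highest of the three numbers measured so far. Compound 2, `CC(C)C[C@@H](c1nc2ccc(C(=O)O)cc2n1C)N1C(=O)N(c2ccc(Oc3ccccc3)cc2)C(C)(C)C1=O`, gives 105000 nM in this assay, which sits within the usual scatter of the number for compound 1, so the two cannot be told apart. Compound 3, `CC(C)C[C@@H](c1nc2ccc(C(=O)O)cc2n1C)N1C(=O)CN(c2ccc(Oc3ccc(Cl)cc3)cc2)C1=O`, gives 2560 nM in this assay, well beyond the scatter from compound 1; compound 3 differs from compound 1 in more than one place, so the two values show only that such a combination of changes reaches a far lower number.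

The step followed here leads to compound 4, `CC(C)[C@@H](c1nc2ccc(C(=O)O)cc2n1C)N1C(=O)CN(c2ccc(Oc3ccccc3)cc2)C1=O`, which is not yet measured. Compound 4 differs from compound 1 in a single place: methyl in place of hydrogen on a saturated chain carbon bound to two saturated chain carbons. Within the data shown here, no pair among the measured compounds isolates this change, so there is no direct precedent for its size. In the absence of such a precedent, compound 4 is expected to give a number close to that of compound 1, with a step of a 1.9-fold lower number from compound 1 to compound 4 (0.28 log units; within the scatter) that may not exceed the scatter. Compound 4 is therefore estimated at 110000 nM in this assay, within a range from 30000 nM to 400000 nM.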

Compound 4, half-maximal inhibitory concentration: 175000 nM
Beside the measured number, compound 4's estimate is 1.6-fold (0.20 log units) below it, within the range that was stated.
By their numbers in this assay, from the lowest: compound 3; then compounds 2, 4 and 1 (each within the scatter of the next).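

Within the data shown here, the first pair in this account that differs in only one place reads, in this assay, as a 1.2-fold lower number from compound 1 to compound 4 (0.08 log units; within the scatter). Methyl in place of hydrogen on a saturated chain carbon bound to two saturated chain carbons, the same difference as ethyl to isopropyl, therefore gives a number that cannot be told apart from that of the parent compound, so this single change has no effect on the number that can be read beyond the scatter. No measurement at hand offers an explanation for this result.

The compounds shown leave open whether a different group at this place, such as tert-butyl, a cyclopropyl ring or an amine, would produce a step beyond the scatter. They also leave open which of the several places in which compound 3 differs from compound 1 accounts for the fact that compound 3 gives 2560 nM as its number, as no pair shown separates those places.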